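The compounds below may be only part of what the source reports. "The series", "measured", "known", "first", "only" and "open" are said of these compounds alone.

Compound 1 `NS(=O)(=O)NCC1CCN(c2cc(-c3ccccc3)ncn2)CC1` carries a sulfamoylamino group on a methylene attached to the saturated ring of the shared core. In a functional assay on M21 cells (Homo sapiens) for antiproliferative activity, read by sulforhodamine B assay, with a stated time of 48 h (on this read-out lower numbers stand for stronger inhibition of growth and higher numbers for weaker inhibition of growth), compound 1 gives only a limit of the assay, > 100000 nM. Compound 2 `COc1ccc(-c2cc(N3CCC(CNS(N)(=O)=O)CC3)ncn2)cc1` likewise returns only a limit, > 100000 nM, as noted in the limit of > 100000 nM in this assay, at which 2 of the 3 values shown sit. Compound 3 `COC(=O)c1ccc(-c2cc(N3CCC(CNS(N)(=O)=O)CC3)ncn2)cc1` gives 14100 nM, and the change from compound 1 to compound 3 reads an at least 7.0-fold lower number from compound 1 to compound 3 (0.85 log units; beyond the scatter), while a step that the two limits leave unreadable from compound 1 to compound 2 and an at least 7.0-fold lower number from compound 2 to compound 3 (0.85 log units; beyond the scatter). Compound 4 `NS(=O)(=O)NCCC1CCN(c2cc(-c3ccccc3)ncn2)CC1` differs from compound 1 by (sulfamoylamino)methyl in place of sulfamoylamino on a saturated chain carbon bound to a saturated ring carbon. Within the data shown here, none of the measured steps touches this chain; all concern the aromatic substituent. No step beyond the scatter is therefore expected in this assay, and compound 4 is estimated at 150000 nM (range 50000 nM to 500000 nM), a step that the limit leaves unreadable from compound 1 to compound 4.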

Compound 4, concentration for 50% growth inhibition: > 100000 nM
Compound 4 was reported as a limit (the forecaster's own chance of this, stated with the estimate: 85%); the middle value does not contradict the limit.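

Compound 1 and compound 4 both sit at a limit, so no step can be read between them: the limit of > 100000 nM in this assay, at which 3 of the 4 values shown sit. On these data alone, whether 2-(sulfamoylamino)ethyl in place of (sulfamoylamino)methyl changes growth inhibition at all remains open.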